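Swapping bromo for methyl on a weak growth inhibitor

The source may hold more compounds than are shown below. What is called first, only, known or untested is meant among the compounds shown, and "the series" means these compounds.

- Compound 1 `Cc1ccc(-c2c(CNC(C)(C)C)c(C(=O)O)nn2-c2ccccc2)cc1`: > 688000 nM (a limit of the assay, not a number)
- Compound 2 `CC(C)(C)NCc1c(C(=O)O)nn(-c2ccc(Cl)cc2)c1-c1ccc(Br)cc1`: 221000 nM

Both compounds were tested in a functional assay on MCF7 cells (Homo sapiens) for inhibition, read by sulforhodamine B assay, with a stated time of 48 h; on this read-out higher numbers stand for weaker inhibition of growth and lower numbers for stronger inhibition of growth. Among the compounds with values here, compound 2, at 221000 nM, holds the only actual number so far, so there is no measured ladder on which to rank it.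

The next compound is compound 3 `Cc1ccc(-c2c(CNC(C)(C)C)c(C(=O)O)nn2-c2ccc(Cl)cc2)cc1`. It differs from compound 2 in one place: methyl in place of bromo on an aromatic carbon. Within the data shown here, no measured pair shows directly what this swap does in this assay, so any expectation is loose. Compound 1 also carries the 4-methylphenyl group, and its > 688000 nM is a limit. That points towards a modest move to weaker growth inhibition, meaning a higher number. The expected change is a 1.8-fold higher number from compound 2 to compound 3 (0.26 log units; within the scatter). Compound 3 is estimated at 400000 nM, with an expected range of 170000 nM to 900000 nM.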

Compound 3, concentration for 50% growth inhibition: > 629000 nM
Compound 3: only a limit was reported (the forecaster's own chance of this, stated with the estimate: 35%); at least 1.5-fold (0.19 log units) between middle value and limit.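

In this assay compound 3 gives > 629000 nM, which is a limit and not a number. Even so, replacing the 4-bromophenyl group with 4-methylphenyl gives a step that can be sized, an at least 2.8-fold higher number from compound 2 to compound 3 (0.45 log units; beyond the scatter) and so, in this one pair, bromo at this place goes with stronger inhibition of growth than methyl does. The step between compound 1 and compound 3, which would show what chloro in place of hydrogen does, cannot be read, as both compounds carry only limits.

From the compounds shown here alone, how far compound 3 really lies past its limit stays open, so the full size of the swap is unknown. Going by these compounds, whether fluoro, a methoxy group or an amine at this place would behave more like bromo or more like methyl also stays open.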